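Notes on the step from compound 3 to compound 4

This account rests on a few compounds, and the source may have more. Where it says the series, first, only, none or still open, it means among the compounds named here.

Three compounds of the series carry numbers in a functional assay for agonist activity at G protein-coupled receptor 88 (Homo sapiens), read by HTRF and cAMP accumulation; a lower number here means that less compound is needed, a higher number that more compound is needed for the effect. Compound 1 `CC(C)C[C@H](N)CN(C(=O)[C@@H]1C[C@H]1c1ccccc1)c1cccc(-c2ccccc2)c1` gives 23000 nM in this assay. Compound 2 `Cc1cccc(-c2ccc(N(C[C@@H](N)CC(C)C)C(=O)[C@@H]3C[C@H]3c3ccccc3)cc2)c1` gives 1200 nM. Compound 3 `CC[C@H](C)[C@H](N)CN(C(=O)[C@@H]1C[C@H]1c1ccccc1)c1ccc(-c2ccc(Oc3ccccc3)cc2)cc1` gives 94 nM, the lowest of the three numbers; the gap to compound 2 lies beyond the usual scatter, and the gap to compound 1 is wider still. Within these three, the lower numbers belong to the compounds with the longer extension on the aryl side, with compound 3 at the end of that run; no compound among the three goes against this, but three compounds are a thin basis.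

Compound 4 `CC[C@H](C)[C@H](N)CN(C(=O)[C@@H]1C[C@H]1c1ccccc1)c1ccc(-c2ccc(CNC)cc2)cc1` has not been measured. Its structure departs from compound 3 in one place: (methylamino)methyl in place of phenoxy on an aromatic carbon. Among the measured compounds shown here, no measured pair carries this particular change, so its effect cannot be read off directly.

The expectation is that the step from compound 3 to compound 4 in this assay is upward and beyond the scatter, as a 7.4-fold higher number from compound 3 to compound 4 (0.87 log units; beyond the scatter), because compound 3 at 94 nM is the member that carries the phenoxy group being removed. Compound 4 is accordingly estimated at 700 nM, with a range from 150 nM to 3500 nM.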

Compound 4, half-maximal effective concentration: 6400 nM
Beside the measured number, compound 4's estimate is 9.1-fold (0.96 log units) below it, and the stated range ends below it.
By their numbers in this assay, from the lowest: compound 3; then compound 2; then compound 4; then compound 1.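

In this assay, (methylamino)methyl in place of phenoxy on an aromatic carbon, para to a large group, gives a 68-fold higher number from compound 3 to compound 4 (1.83 log units; beyond the scatter) as a large step and the first in the series that can be read at a single place. The earlier compounds shown here differ from one another in more than one place, so they could not isolate this position; this pair shows that the number responds strongly to the group held there. No measurement at hand accounts for the size of this step.

The change removes a six-membered aromatic ring of carbon only and introduces a nitrogen-bearing chain with a hydrogen-bond donor in the same step, so the compounds shown do not separate the loss of the one from the arrival of the other. Going by these compounds, whether a methoxy group, a benzyloxy group or a carboxylic acid at the same place would give a number nearer that of compound 3 or that of compound 4 remains open, as does whether this step would have the same size on a different amine side chain.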